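The source may hold more compounds than are shown below. What is called first, only, known or untested is meant among the compounds shown, and "the series" means these compounds.

Series notes, antiproliferative read-out. The two measured compounds share a core but differ on both aryl arms. Compound 1 `COc1ccc(-c2ccnc(Nc3ccc([N+](=O)[O-])cc3)n2)cc1` gives 770 nM in a functional assay on MCF7 cells (Homo sapiens) for antiproliferative activity, read by MTT assay; on this read-out higher numbers stand for weaker inhibition and lower numbers for stronger inhibition. Compound 2 `Cc1cccc(Nc2nccc(-c3ccc(Cl)cc3Cl)n2)c1` gives 249000 nM in this assay, the highest of the two numbers recorded, and its nearest neighbour is compound 1 at a gap well beyond the scatter. Among the compounds with values here, no step between two measured compounds that differ in one place is available, so the effect of a single substituent swap on this core has not been observed directly.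

Compound 3 `COc1cccc(Nc2nccc(-c3ccc(Cl)cc3Cl)n2)c1` is the next candidate. It is derived from compound 2 by one change: methoxy in place of methyl on an aromatic carbon. Both groups are small and uncharged, and the only counted difference is one added oxygen acting as a hydrogen-bond acceptor. Without any measured single-point step to lean on, the expectation for this assay is a step of no clear direction, small and probably within the scatter, so a 1.4-fold lower number from compound 2 to compound 3 (0.14 log units; within the scatter) is the expected move. Compound 3 is therefore estimated at 180000 nM in this assay, with a plausible range from 50000 nM to 600000 nM.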

Compound 3, half-maximal inhibitory concentration: 192000 nM
Beside the measured number, compound 3's estimate is 1.1-fold (0.03 log units) below it, within the range that was stated.
By their numbers in this assay, from the lowest: compound 1; then compounds 3 and 2 (each within the scatter of the next).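

In this assay, within the data shown here, methoxy in place of methyl on an aromatic carbon, meta to a large group, gives a 1.3-fold lower number from compound 2 to compound 3 (0.11 log units; within the scatter); this is the first reading of a single swap on the shared core, and the two compounds cannot be told apart on this read-out. Among these compounds, the earlier pair differed on both aryl arms and could not isolate any one substituent, whereas this pair shows that, with the other arm held constant, adding one hydrogen-bond acceptor oxygen at this position gives no resolvable step, and both compounds remain far weaker than the sub-micromolar number of compound 1 only as printed values, not as a single-place comparison. Nothing measured here speaks to the reason for this outcome.

From the compounds shown here alone, whether an amine, a carboxylic acid or a longer chain such as butoxy at this position would give a step beyond the scatter remains open. Among the compounds shown here, also open is how much of the large gap to compound 1 belongs to each aryl arm, as no single-place step connects compound 1 to compound 2 or compound 3.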